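The compounds below may be only part of what the source reports. "The series", "measured", "known", "first", "only" and "open" are said of these compounds alone.

Compound 2 `Cc1nc(S(C)(=O)=O)ccc1Oc1ncnc(OC2CCN(C(=O)SC(C)C)CC2)c1F` gives 6.8 nM in a functional assay on isolated protein for inhibition of Glucose-dependent insulinotropic receptor (Homo sapiens), read by HTRF and cAMP accumulation; on this read-out higher numbers stand for an effect only at larger amounts of compound and lower numbers for an effect already at smaller amounts. Compound 1 `Cc1nc(S(C)(=O)=O)ccc1Oc1ncnc(OC2CCN(C(=O)O[C@H](C)C(F)(F)F)CC2)c1F`, carrying 1-(trifluoromethyl)ethoxy rather than isopropylsulfanyl on the carbonyl carbon, gives 9.2 nM, and the step of a 1.4-fold lower number from compound 1 to compound 2 (0.13 log units; within the scatter) stays within the scatter, so compound 2 stands alongside compound 1 rather than apart from it. Compound 3 `Cc1nc(S(C)(=O)=O)ccc1Oc1ncnc(OC2CCN(C(=O)SC3CC3)CC2)c1F` differs from compound 2 by cyclopropyl in place of isopropyl on a sulfur. Among the measured compounds shown here, the only step that bears on this change, from compound 1 to compound 2, also altered the group on the carbonyl and stayed within the scatter, so no movement beyond the scatter is expected, an estimated step of a 1.0-fold higher number from compound 2 to compound 3 (0.01 log units; within the scatter). Compound 3 is expected to give 7 nM, between 3 nM and 17 nM.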

Compound 3, half-maximal effective concentration: 24.9 nM
Beside the measured number, compound 3's estimate is 3.6-fold (0.55 log units) below it; measured number outside the range, above it.
By their numbers in this assay, from the lowest: compounds 2 and 1 (each within the scatter of the next); then compound 3.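

In this assay the group on the sulfur turns out to matter: cyclopropyl in place of isopropyl, with the same count of heavy atoms, gives a 3.7-fold higher number from compound 2 to compound 3 (0.56 log units; beyond the scatter) and so moves the number beyond the scatter, which the earlier pair did not show. Against the 1-(trifluoromethyl)ethoxy carbamate there is likewise a 2.7-fold higher number from compound 1 to compound 3 (0.43 log units; beyond the scatter) on the same side. Nothing measured here tells why closing the three-membered ring raises the number. Going by these compounds, whether tert-butyl or a longer chain such as n-butyl on the sulfur keeps the lower number stays open, as does how an amine on the carbonyl carbon would behave.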